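A few compounds are considered here, and "the series" means these few. Any claim that something is new, unique, unknown or untested is made for them only; others in the source may bear on it.

Going by the values given here, in a functional assay on MDA-MB-231 cells (Homo sapiens) for inhibition, read by MTT assay, with a stated time of 48 h (on this read-out lower numbers stand for stronger inhibition and higher numbers for weaker inhibition), two compounds built on the same core have numbers so far. Compound 1 `COc1ccc(N(C)c2nc(C)nc3ccccc23)cc1C(=O)NCC[Se]C#N` gives 1250 nM, while compound 2 `COc1ccc(N(C)c2nc(C)nc3ccccc23)cc1OCC[Se]C#N` gives 13 nM, the lower of the two and so the stronger inhibition. Compound 3 `COc1ccc(N(C)c2nc(C)nc3ccccc23)cc1C[Se]C#N` keeps that core and differs from compound 2 by a group of 4 heavy atoms (2 carbon, 1 nitrogen, 1 selenium; no ring) in place of a group of 6 heavy atoms (3 carbon, 1 nitrogen, 1 oxygen, 1 selenium; no ring), on an aromatic carbon. The group sits ortho to a methoxy group.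

Among the compounds with values here, only one measured step bears on this change: a 96-fold lower number from compound 1 to compound 2 (1.98 log units; beyond the scatter). It is large and beyond the scatter, and it also swaps the group on that same aromatic carbon, so the number clearly can move a long way with this group. That single step gives no rule for the new group. Starting from the lower of the two numbers, a rise is the more likely outcome, and the expected step is a 5.4-fold higher number from compound 2 to compound 3 (0.73 log units; beyond the scatter). For compound 3 the estimated value is 70 nM, with an expected range from 10 nM to 600 nM.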

Compound 3, half-maximal inhibitory concentration: 153 nM
Compound 3: the middle estimate sits 2.2-fold (0.34 log units) below what was measured; the range from low to high includes it.
By their numbers in this assay, from the lowest: compound 2; then compound 3; then compound 1.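

The group on this aromatic carbon now has three measured forms, and in this assay the smallest of them, with 4 heavy atoms, falls in the middle: the change gives a 12-fold higher number from compound 2 to compound 3 (1.07 log units; beyond the scatter), while replacing the largest group gives an 8.2-fold lower number from compound 1 to compound 3 (0.91 log units; beyond the scatter). Among these three compounds, the number therefore does not simply follow group size, as the lowest number belongs to the group of 6 heavy atoms, which is neither the smallest nor the largest. No measurement at hand explains this order.

Going by these compounds, it remains open whether the low number of compound 2 depends on the oxygen in its group, on the length of that group, or on both. These compounds do not show how a longer chain with the same selenium and nitrile end, or an amine in place of that oxygen, would behave.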